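From Amino to Methoxy on the Shared Core

A few compounds are considered here, and "the series" means these few. Any claim that something is new, unique, unknown or untested is made for them only; others in the source may bear on it.

Compound 2 `Nc1ccccc1/C=C/c1ccccc1O` carries an amino group on one aromatic carbon of the shared core. Within the data shown here, in a functional assay on MCF7 cells (Homo sapiens) for inhibition, read by MTT assay, with a stated time of 2 days (on this read-out lower numbers stand for stronger inhibition and higher numbers for weaker inhibition), compound 2 gives 39 ug/mL, which is the higher of the two numbers measured so far. Among the measured compounds shown here, its only neighbour is compound 1 `Oc1ccccc1/C=C/c1ccccc1O`, the hydroxy analogue, and in this assay compound 1 gives 23 ug/mL. The step between them, a 1.7-fold higher number from compound 1 to compound 2 (0.23 log units; within the scatter), lies within the scatter, so the two compounds cannot be ordered on this evidence.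

Compound 3 `COc1ccccc1/C=C/c1ccccc1O` differs from compound 2 by methoxy in place of amino on an aromatic carbon. For the measured compounds named here, the only measured step that touches the same aromatic carbon is a 1.7-fold higher number from compound 1 to compound 2 (0.23 log units; within the scatter), and it was small. Going by the values given here, no measured step involves a methoxy group, so the effect of this replacement is not tested here. Exchanging amino for methoxy is therefore expected to give a change no larger than the scatter, with the step from compound 2 to compound 3 estimated as a 1.0-fold higher number from compound 2 to compound 3 (0.01 log units; within the scatter). In this assay compound 3 is expected to give about 40 ug/mL, with a range from 15 ug/mL to 110 ug/mL.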

Compound 3, half-maximal inhibitory concentration: 17.9 ug/mL
Beside the measured number, compound 3's estimate is 2.2-fold (0.35 log units) above it; measured number inside the range.
By their numbers in this assay, from the lowest: compounds 3, 1 and 2 (each within the scatter of the next, the first and the last beyond it).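

In this assay, among these compounds, the exchange of amino for methoxy on this aromatic carbon gives the first step at this position that lies beyond the scatter (a 2.2-fold lower number from compound 2 to compound 3 (0.34 log units; beyond the scatter)), although it is only modest in size. Methyl in place of hydrogen on the oxygen at the same position stays within the scatter (a 1.3-fold lower number from compound 1 to compound 3 (0.11 log units; within the scatter)), so compound 1 and compound 3 cannot be ordered, and compound 2 stands apart from compound 3 but not from compound 1. No measurement among those shown accounts for the difference between compound 2 and compound 3.

Among the compounds shown here, the case for sensitivity at this position therefore rests on a single modest step, and it remains open whether that step reflects a wider trend or only this pair of groups. Other groups on the same aromatic carbon, such as ethoxy, a longer chain or a carboxylic acid, would show whether the number moves further from that of compound 3, and the hydroxy group on the other side of the shared core remains untested in these three compounds.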